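The compounds below may be only part of what the source reports. "The series", "measured", "known", "first", "only" and "open" are said of these compounds alone.

Measured in a functional assay on MCF7 cells (Homo sapiens) for cytotoxicity, read by MTT assay, with a stated time of 2 days, tested at 100 uM; on this read-out lower numbers stand for a stronger effect and higher numbers for a weaker effect at the one concentration tested:

Compound 1 `CC(=O)c1cc(-c2ccc(F)cc2)cc2cc(-c3ccccc3)[nH]c12`: 36.4%
Compound 2 `COc1ccc(-c2cc(C(C)=O)c3[nH]c(-c4ccccc4)cc3c2)cc1`: 30.8%
Compound 3 `CC(=O)c1cc(/C=C/c2ccc(F)cc2)cc2cc(-c3ccc(F)cc3)[nH]c12`: 42.2%

Compound 1 and compound 2 share one core and differ in a single place: methoxy in place of fluoro on an aromatic carbon. The step this made in this assay is a number 5.6 percentage points lower from compound 1 to compound 2 (within the scatter), so the two numbers cannot be told apart. Compound 3 rests on a different core; the difference between the two cores is not broken down here. Among the three, compound 3 has the highest number, yet only its gap to compound 2 lies beyond the scatter, while its gap to compound 1 does not.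

Compound 4 `COc1ccc(-c2cc3cc(/C=C/c4ccc(F)cc4)cc(C(C)=O)c3[nH]2)cc1` comes from compound 3 by the same change: methoxy in place of fluoro on an aromatic carbon. The place is described in the same words for both pairs. Going by the values given here, since the one measured instance of this change, a number 5.6 percentage points lower from compound 1 to compound 2 (within the scatter), stayed within the scatter, a step of similar size is expected from compound 3 to compound 4, namely a number 5.2 percentage points lower from compound 3 to compound 4 (within the scatter). Compound 4 is therefore estimated at 37% in this assay, with a likely range from 27% to 47%.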

Compound 4, a percentage reported as activity, at one concentration (the size of the read-out at that concentration, not a potency): 47.6%
Compound 4: middle estimate off by 10.6 percentage points, on the low side, outside the stated range (above it).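

In this assay, replacing 4-fluorophenyl with 4-methoxyphenyl on the core of compound 3 gave a number 5.4 percentage points higher from compound 3 to compound 4 (within the scatter). Neither this step nor the earlier one can be told from the ordinary scatter of repeated measurements, and the two steps cannot be told from each other, so nothing here separates how the change behaves on the two cores: the same change on two cores in this assay, a number 5.6 percentage points lower (within the scatter) from compound 1 to compound 2 and a number 5.4 percentage points higher (within the scatter) from compound 3 to compound 4, 11 percentage points apart, within the scatter of two such steps

This does not show that the change is truly without effect, or that it would carry over equally to other cores, since two pairs tested at a single concentration can reveal only a sizeable shift.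

At this place on the ring, the compounds shown carry only fluoro and methoxy, so it stays open how an amine, a carboxylic acid or a longer chain such as butoxy would read out. On these data alone, it also stays open which part of the difference between the core of compound 1 and the core of compound 3 matters in this read-out.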